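From cyclopropyl to furan-2-yl on a shared core

The source may report more compounds than this note shows. Statements on the series, on what has been measured and on what is new or still open speak of the compounds shown alone.

In a functional assay on SW620/5-FU cells (Homo sapiens) for cytotoxicity, read by MTT assay, with a stated time of 48 h, in the presence of a further agent that is not named here (a lower number here means that less compound is needed, a higher number that more compound is needed for the effect), compound 1 `Cc1nn(C)c2nc(NNC(=O)Nc3cc(Cl)nc(Cl)c3)cc(C3CC3)c12` gives 80800 nM. Compound 3 `Cn1ncc2c(-c3ccccc3)cc(NNC(=O)Nc3cc(Cl)nc(Cl)c3)nc21` gives 76900 nM, which lies within the scatter of compound 1. Compound 2 `Cn1nc(C(F)(F)F)c2c(-c3ccccc3)cc(NNC(=O)Nc3cc(Cl)nc(Cl)c3)nc21` gives the lowest number of the three, 13100 nM.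

The next compound, compound 4 `Cc1nn(C)c2nc(NNC(=O)Nc3cc(Cl)nc(Cl)c3)cc(-c3ccco3)c12`, departs from compound 1 in one place: furan-2-yl in place of cyclopropyl on an aromatic carbon. In words, furan-2-yl stands in place of cyclopropyl on an aromatic carbon. Among the compounds with values here, the only measured step is a 5.9-fold higher number from compound 2 to compound 3 (0.77 log units; beyond the scatter). It concerns hydrogen in place of trifluoromethyl, a different change, so it shows what a modest step looks like in this assay but gives no direction for this one.

The nearer guide is a comparison of two values. Compound 1 carries cyclopropyl where compound 3, which also differs in a second place, carries phenyl, and compound 3 still stands at 76900 nM, within the scatter of compound 1. On that basis, no step beyond the scatter is expected for an aromatic ring entering here.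

The estimated change is a 1.3-fold lower number from compound 1 to compound 4 (0.13 log units; within the scatter). For compound 4 the estimated value is 60000 nM, with an expected range from 22000 nM to 130000 nM.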

Compound 4, half-maximal effective concentration: > 100000 nM
Compound 4 ended at the assay's limit; the forecaster's own chance of this, stated with the estimate: 10%; middle value at least 1.6-fold (0.22 log units) from the limit.
By their numbers in this assay, from the lowest: compound 2; then compounds 3 and 1 (each within the scatter of the next). At a limit, above all of these: compound 4.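

In this assay, within the data shown here, the change from cyclopropyl to furan-2-yl gives the first step that can be read at this aromatic carbon, opposite the ring nitrogen, with nothing else on the shared core altered: it is an at least 1.2-fold higher number from compound 1 to compound 4 (0.09 log units; that floor lies within the scatter). This shows that placing this five-membered aromatic ring here does not bring the number down, but the floor of the step does not establish a rise, and its true size remains unread. The value of compound 4 is a limit of the assay and not a number, and only this compound sits there: the limit of > 100000 nM in this assay, at which 1 of the 4 values shown sits.

The compounds shown leave open what an amine, a methoxy group or a carboxylic acid would give on this same aromatic carbon, where a value inside the range of the assay could show whether the position responds to a change of group at all. As far as these compounds go, it also remains open whether furan-2-yl would give a readable value on the core of compound 2, which carries trifluoromethyl and gives 13100 nM.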